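Trifluoromethyl in place of methoxy: compound 3 to compound 4

The compounds below may be only part of what the source reports. "The series", "measured", "known", "first", "only" and "open" are said of these compounds alone.

In a functional assay on BT-483 cells (Homo sapiens) for cytotoxicity, read by MTT assay, with a stated time of 24 h (a higher number here means a weaker inhibitor, a lower number a stronger inhibitor), compound 1 (`CCNc1cc(-c2ccc(NC(=O)Nc3ccc(C(F)(F)F)cc3)cc2OC)ccn1`) gives 25600 nM, compound 2 (`CCNc1cc(-c2ccc(NC(=O)Nc3cccc(Cl)c3)cc2F)ccn1`) gives 18500 nM and compound 3 (`CCNc1cc(-c2ccc(NC(=O)Nc3ccc(OC)cc3)cc2F)ccn1`) gives 19600 nM. Compound 3 lies within the scatter of both other compounds, so the three values do not separate.

The next compound is compound 4 (`CCNc1cc(-c2ccc(NC(=O)Nc3ccc(C(F)(F)F)cc3)cc2F)ccn1`), reached from compound 3 by trifluoromethyl in place of methoxy on an aromatic carbon, para to a large group. For the measured compounds named here, the only measured step at this aryl group is a 1.1-fold higher number from compound 2 to compound 3 (0.03 log units; within the scatter), with 4-methoxyphenyl in place of 3-chlorophenyl, and it stays within the scatter. Going by the values given here, no matched pair for the methoxy to trifluoromethyl exchange has been measured. Compound 1, which carries the 4-(trifluoromethyl)phenyl group, gives 25600 nM, again within the scatter of compound 3.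

No step beyond the scatter is therefore expected in this assay. The expected step is a 1.1-fold higher number from compound 3 to compound 4 (0.03 log units; within the scatter). For compound 4 the estimated value is 21000 nM, with an expected range of 13000 nM to 32000 nM.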

Compound 4, half-maximal inhibitory concentration: 26800 nM
Estimate against measurement, compound 4: 1.3-fold (0.11 log units) below; the measured number falls inside the stated range.
By their numbers in this assay, from the lowest: compounds 2, 3, 1 and 4 (each within the scatter of the next).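

In this assay, 4-(trifluoromethyl)phenyl in place of 4-methoxyphenyl now forms a measured matched pair, and the exchange stays within the scatter (a 1.4-fold higher number from compound 3 to compound 4 (0.14 log units; within the scatter)). Set against 3-chlorophenyl, the 4-(trifluoromethyl)phenyl group also stays within the scatter (a 1.4-fold higher number from compound 2 to compound 4 (0.16 log units; within the scatter)), and the second varied place gains its first matched pair, fluoro in place of methoxy, again within the scatter (a 1.0-fold higher number from compound 1 to compound 4 (0.02 log units; within the scatter)). Nothing further is available to account for values that do not separate.

From the compounds shown here alone, only methoxy, trifluoromethyl and chloro appear on this aryl group, so it remains open whether an amine or a carboxylic acid there would give a step beyond the scatter. Going by these compounds, the ethyl group on the shared core stays constant throughout, which leaves a longer chain at that place equally open.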